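The compounds below may be only part of what the source reports. "The series", "measured", "known", "first", "only" and "open" are said of these compounds alone.

Compound 2 `CN1C(=S)[C@@H](NC(=O)c2nc(Cc3ccccc3)n(CCCCCC#N)n2)COc2ccccc21` is known in a toxicity assay on HT-29 cells (Homo sapiens) for cytotoxicity (on this read-out higher numbers stand for lower toxicity in this test and lower numbers for higher toxicity in this test), only as a limit: compound 2 gives > 100000 nM, which is a limit of the assay rather than a number. Its parent, compound 1 `CN1C(=S)[C@@H](NC(=O)c2n[nH]c(Cc3ccccc3)n2)COc2ccccc21`, stands at a limit as well, for in this assay compound 1 gives > 50000 nM. The step that the two limits leave unreadable from compound 1 to compound 2 cannot be sized because the limit of > 100000 nM in this assay, at which 1 of the 2 values shown sits, and the limit of > 50000 nM in this assay, at which 1 of the 2 values shown sits, both close off the read-out.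

The next compound, compound 3 `CN1C(=S)[C@@H](NC(=O)c2nc(Cc3ccccc3)n(C3CCNC3)n2)COc2ccccc21`, differs from compound 2 in one place: pyrrolidin-3-yl in place of 5-cyanopentyl on an aromatic nitrogen. The only measured step that bears on this change is the unreadable one, so there is no sized precedent for what a change on the aromatic nitrogen does here; all that is shown is that neither compound 1 nor compound 2 reached a measurable value. On that basis compound 3 is expected to remain at or near a limit, with no step beyond the scatter in this assay. The estimate for compound 3 is 100000 nM, within a range from 30000 nM to 300000 nM. This estimate corresponds to an expected step of a number no higher from compound 2 to compound 3 (the limit leaves the size open).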

Compound 3, half-maximal cytotoxic concentration: > 100000 nM
Compound 3 ended at the assay's limit; the forecaster's own chance of this, stated with the estimate: 85%; the middle value sits exactly at the limit.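

In this assay compound 3 gives > 100000 nM, which is a limit of the assay and not a number, so the steps among compound 1, compound 2 and compound 3 cannot be read: the limit of > 100000 nM in this assay, at which 2 of the 3 values shown sit.

The compounds shown leave open what size of step, if any, a change on the aromatic nitrogen produces in this assay.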